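The compounds below may be only part of what the source reports. "The series", "measured", "known", "first", "only" and "open" are said of these compounds alone.

Working notes on the series, read in an ADME assay on the whole organism (Rattus norvegicus) for metabolic stability, at a dose of 1 mg/kg by the intravenous route; on this read-out higher numbers stand for a longer-lived compound and lower numbers for a shorter-lived compound. Compound 1 (`COc1ccc(F)cc1-c1ccnc2[nH]c(C3=CCC(N[C@@H](C(=O)O)C(C)C)CC3)cc12`) gives 0.68 h, compound 2 (`COc1ccc(F)cc1-c1ccnc2[nH]c(C3=CCN([C@H]4CC[C@H](C(=O)O)CC4)CC3)cc12`) gives 3.3 h, and compound 3 (`COc1ccc(F)cc1-c1c(F)cnc2[nH]c(C3=CCN([C@H]4CC[C@H](C(=O)O)CC4)CC3)cc12`) gives 3.5 h. Compound 3 thus stands level with compound 2 within the scatter, and both lie well clear of compound 1.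

Compound 4 (`COc1ccc(F)cc1-c1c(F)cnc2[nH]c(C3=CCN([C@H]4CC[C@H](CC(=O)O)CC4)CC3)cc12`) is the next entry. The change is carboxymethyl in place of carboxy on a saturated ring carbon, so that 4-carboxycyclohexyl becomes 4-(carboxymethyl)cyclohexyl.

Going by the values given here, the only measured single-place step, a 1.1-fold higher number from compound 2 to compound 3 (0.03 log units; within the scatter), is fluoro in place of hydrogen on an aromatic carbon and lies within the scatter. It does not involve the carboxy group. Compound 1 differs from compound 2 in more than one place and gives no clean reading. Among the compounds with values here, no measured step therefore speaks directly to this change, and no shift beyond the scatter is expected in this assay. The expected step is a 1.3-fold lower number from compound 3 to compound 4 (0.10 log units; within the scatter), slightly downward and within the scatter. Compound 4 is estimated at 2.8 h, with an expected range of 1.3 h to 5.5 h.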

Compound 4, half-life: 2.8 h
For compound 4 middle estimate and measured number coincide at the digits printed; the measured number falls inside the stated range.
By their numbers in this assay, from the lowest: compound 1; then compounds 4, 2 and 3 (each within the scatter of the next).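

In this assay, going by these compounds alone, replacing 4-carboxycyclohexyl with 4-(carboxymethyl)cyclohexyl gives a 1.3-fold lower number from compound 3 to compound 4 (0.10 log units; within the scatter) and provides the first reading of a change on the saturated ring carbon. The earlier single-place step concerned fluoro on an aromatic carbon and did not touch this group. Carboxy and carboxymethyl at this position therefore cannot be told apart on this read-out, and the added chain length leaves the number within the scatter in this one pair. No measurement beyond the half-life bears on this result.

The compounds shown leave open whether a longer chain ending in a carboxylic acid, or a primary amide or tetrazole at the same position, would stay level with compound 3. They also leave open whether the same change reads alike without the aromatic fluoro group.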